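Removing the chloro from the urea aryl of compound 2

The compounds below may be only part of what the source reports. "The series", "measured", "known", "first", "only" and "open" are said of these compounds alone.

Compound 2 `COc1cc(Cl)cc(-c2nn(-c3cccc(NC(=O)Nc4ccc(Cl)c(C(F)(F)F)c4)c3)cc2-c2ccncc2)c1` sits level with compound 1 `O=C(Nc1cccc(-n2cc(-c3ccncc3)c(-c3cc(O)cc(Cl)c3)n2)c1)Nc1ccc(Cl)c(C(F)(F)F)c1` in a functional assay on SK-MEL-5 cells (Homo sapiens) for inhibition, read by sulforhodamine B assay, with a stated time of 48 h, tested at 0.1 uM (a lower number here means a stronger effect, a higher number a weaker effect of the compound at the concentration tested), and together they give the highest of the three numbers recorded, with compound 2 at 98% and compound 1 at 98%. Compound 3 `COc1cc(Cl)cc(-c2nn(-c3cccc(NC(=O)Nc4cc(C(F)(F)F)cc(C(F)(F)F)c4)c3)cc2-c2ccncc2)c1` gives 97% in this assay, a number within the scatter of both. Within the data shown here, the only single-point step recorded, no change at the digits printed from compound 1 to compound 2 (within the scatter), shows that exchanging methyl for hydrogen on the ring oxygen left the read-out unchanged.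

Compound 4 `COc1cc(Cl)cc(-c2nn(-c3cccc(NC(=O)Nc4cccc(C(F)(F)F)c4)c3)cc2-c2ccncc2)c1` differs from compound 2 by hydrogen in place of chloro on an aromatic carbon. Among the measured compounds shown here, no recorded step bears directly on the 4-chloro-3-(trifluoromethyl)phenyl group; the nearest information is compound 3, whose different aryl on the urea still gives a number within the scatter of compound 2. On this basis the step from compound 2 to compound 4 is expected to be a number 1 percentage points lower from compound 2 to compound 4 (within the scatter), that is, no movement beyond the scatter. Compound 4 is therefore estimated at 97%, within the range 85% to 105%.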

Compound 4, a percentage reported as activity, at one concentration (the size of the read-out at that concentration, not a potency): 98%
Compound 4: middle estimate off by 1 percentage points, on the low side; measured number inside the range.
By their numbers in this assay, from the lowest: compounds 3, 1, 2 and 4 (each within the scatter of the next).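

In this assay, replacing the chloro that stands ortho to a trifluoromethyl group with hydrogen gives no change at the digits printed from compound 2 to compound 4 (within the scatter), so the read-out does not depend on this chloro. Replacing a trifluoromethyl group on the same urea aryl with hydrogen gives a number 1 percentage points higher from compound 3 to compound 4 (within the scatter), which shows that this aryl also keeps its read-out with that second group gone. No measurement offered here accounts for either result.

The compounds shown leave open whether the one remaining trifluoromethyl group can also be replaced by hydrogen, and whether an amine or a carboxylic acid at the former chloro position would move the number beyond the scatter. With all four compounds within the scatter at a single concentration, they also leave open any separation of these compounds by potency.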